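The source may report more compounds than this note shows. Statements on the series, on what has been measured and on what is new or still open speak of the compounds shown alone.

Compound 3 `COc1ncnc2c1c(-c1ccccc1)cn2[C@@H]1O[C@H](CO)[C@@H](O)[C@H]1O` is the reference point of this step. In a functional assay on CEM-DNR-bulk cells (Homo sapiens), read by MTT assay, with a stated time of 72 h (on this read-out lower numbers stand for stronger inhibition and higher numbers for weaker inhibition), compound 3 gives > 20000 nM, which is a limit of the assay and not a number. Compound 1 `CSc1ncnc2c1c(-c1ccccc1)cn2[C@@H]1O[C@H](CO)[C@@H](O)[C@H]1O` gives in this assay > 20000 nM, likewise a limit. Compound 2 `COc1ncnc2c1c(-c1cccs1)cn2[C@@H]1O[C@H](CO)[C@@H](O)[C@H]1O` gives 12100 nM. Of the three values on hand, two sit at the same limit (the limit of > 20000 nM in this assay, at which 2 of the 3 values shown sit). The step that the two limits leave unreadable from compound 1 to compound 3 cannot be read. The step of an at least 1.6-fold higher number from compound 2 to compound 3 (0.21 log units; that floor lies within the scatter) is the only readable one, and its floor lies within the scatter.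

Compound 4 `COc1ncnc2c1c(-c1cc3ccccc3o1)cn2[C@@H]1O[C@H](CO)[C@@H](O)[C@H]1O` differs from compound 3 by 1-benzofuran-2-yl in place of phenyl on an aromatic carbon. Among the compounds with values here, the one measured step that bears on this change is the exchange of thiophen-2-yl for phenyl between compound 2 and compound 3, which gave a higher number; the reverse direction, phenyl giving way to another five-membered heteroaryl, here 1-benzofuran-2-yl, would on that precedent give a lower number. Compound 3 stands at a limit, so the size of any such step cannot be read against it, and the value may again come back as a limit. Compound 4 is estimated at 8000 nM, within 2000 nM and 20000 nM. The expected step is an at least 2.5-fold lower number from compound 3 to compound 4 (0.39 log units; beyond the scatter), a modest move below the limit that cannot be confirmed from the values in hand.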

Compound 4, half-maximal inhibitory concentration: 10800 nM
Beside the measured number, compound 4's estimate is 1.4-fold (0.13 log units) below it; low and high end bracket the measured number.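

In this assay the change to 1-benzofuran-2-yl gives an at least 1.8-fold lower number from compound 3 to compound 4 (0.26 log units; that floor lies within the scatter), so this place now yields a number where phenyl gave only a limit, yet the size of the step cannot be read because compound 3 carries a limit of the assay and not a number: the limit of > 20000 nM in this assay, at which 2 of the 4 values shown sit.

Thiophen-2-yl and 1-benzofuran-2-yl are not separated, with a 1.1-fold lower number from compound 2 to compound 4 (0.05 log units; within the scatter), so the group of 9 heavy atoms shows no readable change against the thiophen-2-yl group at this place.

Among the three methoxy compounds, compound 2 and compound 4 give numbers while compound 3 gives a limit, a pattern that covers these three compounds only and rests on floors within the scatter.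

From the compounds shown here alone, the step between the methylsulfanyl and methoxy groups cannot be read, so what the methylsulfanyl group does beside a thiophen-2-yl or 1-benzofuran-2-yl group remains open. Also open, going by these compounds, is whether an amine or a carboxylic acid on the aromatic group at this place would move the number clear of the scatter.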